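The source may hold more compounds than are shown below. What is called first, only, known or untested is meant among the compounds shown, and "the series" means these compounds.

Measured compounds:
- compound 1, `CO[C@H]1O[C@H](COc2ccc(OC3CCCCC3)cc2)[C@@H](O)[C@H](O)[C@H]1Oc1ccc(C(C)C)cc1`: 18000 nM in a functional assay on HeLa cells (Homo sapiens) for cytotoxicity, read by MTT assay, with a stated time of 48 h; a lower number here means that less compound is needed, a higher number that more compound is needed for the effect
- compound 2, `CO[C@H]1O[C@H](COc2ccc(-c3ccccc3)cc2)[C@@H](O)[C@H](O)[C@H]1Oc1ccc(C(C)C)cc1`: 19000 nM in this assay

Among the measured compounds shown here, compound 1 stands lowest of the two numbers so far, with compound 2 its nearest neighbour; the one measured step, a 1.1-fold higher number from compound 1 to compound 2 (0.02 log units; within the scatter), puts phenyl in place of cyclohexyloxy on an aromatic carbon and leaves the read-out essentially unchanged.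

Compound 3, `CO[C@@H]1O[C@H](COc2ccc(OC3CCCCC3)cc2)[C@@H](O)[C@H](O)[C@H]1Oc1ccc(C(C)C)cc1`, is not yet measured. Against compound 1 the difference is the two compounds have the same atoms and bonds and differ only in configuration as drawn: 1 of 5 stereo elements differ; a stereocentre at a saturated ring carbon is drawn S in compound 1 and R in compound 3. For the measured compounds named here, no measured step bears on a change of configuration alone: the single step on record concerns a substituent on an aromatic carbon elsewhere in the molecule, and it lies within the scatter. There is thus nothing in the series to argue for a step in either direction, and the expectation is a number close to that of compound 1, with a range widened to allow for the untested nature of this kind of change.

Compound 3 is estimated at 18000 nM, with a range from 8000 nM to 40000 nM. The expected step is no change at the digits printed from compound 1 to compound 3 (within the scatter), none beyond the scatter.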

Compound 3, half-maximal effective concentration: 26000 nM
Compound 3: the middle estimate sits 1.4-fold (0.16 log units) below what was measured, within the range that was stated.
By their numbers in this assay, from the lowest: compounds 1, 2 and 3 (each within the scatter of the next).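

Drawing the stereocentre at this saturated ring carbon R instead of S gives a 1.4-fold higher number from compound 1 to compound 3 (0.16 log units; within the scatter) in this assay, so this single inversion does not separate the two compounds in this read-out. Among the compounds shown here, this is the first measured change in the shared core rather than on an aromatic carbon, and like a 1.1-fold higher number from compound 1 to compound 2 (0.02 log units; within the scatter), it stays within the scatter, so neither of the two changes on record has yet produced a readable difference. The configurational comparison is unusually clean, with no substituent change to confound it, and the reason lies in the pair itself: the fact that compounds 1 and 3 differ only in the configuration as drawn.

As far as these compounds go, whether the same inversion would also leave the number unresolved with phenyl in place of cyclohexyloxy remains open, as does the role of the other four stereo elements, since one inversion at one carbon says nothing about them. From the compounds shown here alone, it is also open whether an amine or a carboxylic acid in place of cyclohexyloxy would move the number beyond the scatter, or whether this part of the molecule tolerates such groups as it does phenyl.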